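The compounds below may be only part of what the source reports. "The series", "measured", "known", "first", "only" and "open" are said of these compounds alone.

Measured so far in a functional assay on the whole organism (strain Wistar) for inhibition, with Rattus norvegicus as the target, read by paw edema, with stated times of 60 min and 3 h, at a dose of 100 mg/kg by the oral route; a lower number here means less inhibition, a higher number more inhibition at the dose given (going by the name of the read-out):
compound 1 `CNC(=O)CC1CCc2cc(OC)c(OC)cc21` gives 29%;
compound 2 `COc1cc2c(cc1OC)C(CC(=O)N(C)C)CC2` gives 34.8%;
compound 3 `COc1cc2c(cc1OC)C(CC(=O)NC(C)(C)C)CC2` gives 33.3%.

Compound 2 holds the highest of the three numbers, yet the step of a number 1.5 percentage points lower from compound 2 to compound 3 (within the scatter) and the step of a number 5.8 percentage points higher from compound 1 to compound 2 (within the scatter) both lie within the scatter, so the three compounds cannot be told apart on these data. Compound 4 `CCCCCNC(=O)CC1CCc2cc(OC)c(OC)cc21` differs from compound 2 by pentylamino in place of dimethylamino on a carbonyl carbon. The step that bears most directly on it, the earlier exchange of amino groups on the same carbonyl carbon, was a number 1.5 percentage points lower from compound 2 to compound 3 (within the scatter); the step on the amide-type nitrogen, a number 4.3 percentage points higher from compound 1 to compound 3 (within the scatter), was likewise within the scatter. Every variation of the amide seen so far has stayed within the scatter in this assay, so no step beyond the scatter is expected here either. Compound 4 is expected to give 33%, within 22% to 44%. The expected step is a number 1.8 percentage points lower from compound 2 to compound 4 (within the scatter).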

Compound 4, a percentage reported as inhibition, in the whole organism at one dose (the size of the read-out at that dose, not a potency): 37.7%
Estimate against measurement, compound 4: 4.7 percentage points below; measured number inside the range.
By their numbers in this assay, from the lowest: compounds 1, 3, 2 and 4 (each within the scatter of the next).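

In this assay the amide nitrogen carries a pentyl chain without leaving the scatter: the exchange on the carbonyl carbon gives a number 2.9 percentage points higher from compound 2 to compound 4 (within the scatter) and the exchange of tert-butyl for pentyl gives a number 4.4 percentage points higher from compound 3 to compound 4 (within the scatter). The widest gap among these amides, a number 8.7 percentage points higher from compound 1 to compound 4 (within the scatter), also stays within the scatter, so compound 4 cannot be told apart from the earlier compounds. No evidence is available that bears on this result. The compounds shown leave open whether a chain longer than pentyl, or one ending in an amine or a carboxylic acid, would move the number beyond the scatter.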